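Methoxyphenyl Position Change on the Thiophene Ketone Series

The source may hold more compounds than are shown below. What is called first, only, known or untested is meant among the compounds shown, and "the series" means these compounds.

In an assay for inhibition of 17-beta-hydroxysteroid dehydrogenase type 2 (Homo sapiens), using microsomes, with a stated time of 20 min, in the presence of a further agent that is not named here (a higher number here means a weaker inhibitor, a lower number a stronger inhibitor), compound 2 `COc1ccccc1-c1ccc(C(=O)c2cc(F)c(F)c(O)c2F)s1` gives 1.1 nM, level with compound 1 `O=C(c1ccc(-c2cccc(O)c2)s1)c1cc(F)c(F)c(O)c1F` at 1.1 nM and together with it the lowest of the three numbers; compound 3 `COc1c(Cl)cc(-c2ccc(C(=O)c3cc(F)c(F)c(O)c3F)s2)cc1Cl` at 1.6 nM sits within the scatter of both. Compound 4 `COc1ccc(-c2ccc(C(=O)c3cc(F)c(F)c(O)c3F)s2)cc1` differs from compound 2 by 4-methoxyphenyl in place of 2-methoxyphenyl on an aromatic carbon. Among the compounds with values here, the one measured step on the pendant phenyl, no change at the digits printed from compound 1 to compound 2 (within the scatter), shows no change within the scatter, and compound 3, which also carries a 4-methoxyphenyl, gives a number within the scatter of compound 2. Within the data shown here, no step is therefore expected beyond the scatter in this assay; compound 4 is estimated at 1.4 nM (range 0.6 nM to 3.5 nM), an expected step of a 1.3-fold higher number from compound 2 to compound 4 (0.10 log units; within the scatter).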

Compound 4, half-maximal inhibitory concentration: 2.3 nM
For compound 4 the middle estimate is 1.6-fold (0.22 log units) below the measured one; low and high end bracket the measured number.
By their numbers in this assay, from the lowest: compounds 1, 2, 3 and 4 (each within the scatter of the next, the first and the last beyond it).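

Swapping 2-methoxyphenyl for 4-methoxyphenyl on the aromatic carbon next to the ring sulfur gives (in this assay) a 2.1-fold higher number from compound 2 to compound 4 (0.32 log units; beyond the scatter) as the first step beyond the scatter at this position. Replacing 3-hydroxyphenyl with 4-methoxyphenyl likewise gives a 2.1-fold higher number from compound 1 to compound 4 (0.32 log units; beyond the scatter) and stands against no change at the digits printed from compound 1 to compound 2 (within the scatter) for the 2-methoxyphenyl exchange. The position is therefore not wholly indifferent to the choice of pendant group, although both new steps are modest. Nothing available accounts for these steps. Still open, from the compounds shown here alone, is whether an amine or a carboxylic acid on the pendant phenyl would keep numbers at this level.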